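The source may report more compounds than this note shows. Statements on the series, on what has been measured and on what is new or still open speak of the compounds shown alone.

Measured compounds:
compound 1 `CC(C(=O)NCc1ccc(C(F)(F)F)nc1N(Cc1ccccc1)S(C)(=O)=O)c1ccc(NS(C)(=O)=O)c(F)c1` gives 25 nM in an assay on CHO cells for antagonist activity at transient receptor potential cation channel subfamily V member 1 (Homo sapiens), read by scintillation counting, with a stated time of 5 min; on this read-out lower numbers stand for stronger inhibition and higher numbers for weaker inhibition;
compound 2 `CC(C(=O)NCc1ccc(C(F)(F)F)nc1N(Cc1ccccc1)S(=O)(=O)C(C)C)c1ccc(NS(C)(=O)=O)c(F)c1` gives 6.19 nM.

Compound 2 carries the lowest number of the two, with compound 1 the nearest and the step of a 4.0-fold lower number from compound 1 to compound 2 (0.61 log units; beyond the scatter) being the only one seen. Compound 3 `CC(C(=O)NCc1ccc(C(F)(F)F)nc1N(Cc1ccccc1)S(=O)(=O)c1ccc(F)cc1)c1ccc(NS(C)(=O)=O)c(F)c1` differs from compound 2 by 4-fluorophenyl in place of isopropyl on a sulfonyl sulfur. Within the data shown here, that step replaces an isopropyl with a larger group at the same sulfonyl sulfur; the only measured step at that sulfur, a 4.0-fold lower number from compound 1 to compound 2 (0.61 log units; beyond the scatter), went with growth from methyl to isopropyl. For compound 3 a further step about the size of the scatter, a 1.2-fold lower number from compound 2 to compound 3 (0.09 log units; within the scatter), is therefore expected, giving an estimated 5 nM (range 1.5 nM to 17 nM).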

Compound 3, inhibition constant: 3.87 nM
Compound 3: middle estimate off by 1.3-fold (0.11 log units), on the high side, and the stated range covers the measured number.
By their numbers in this assay, from the lowest: compounds 3 and 2 (each within the scatter of the next); then compound 1.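

At the sulfonyl sulfur, an aromatic ring can stand in place of an alkyl group: in this assay, 4-fluorophenyl in place of isopropyl stays within the scatter (a 1.6-fold lower number from compound 2 to compound 3 (0.20 log units; within the scatter)), while 4-fluorophenyl in place of methyl stays beyond it (a 6.5-fold lower number from compound 1 to compound 3 (0.81 log units; beyond the scatter)). The lower number seen on leaving methyl thus holds for both larger groups, and this assay does not separate them. Nothing available here explains this. Still open, on these data alone, is how plain phenyl would compare with 4-fluorophenyl, and how a longer chain or an amine-bearing chain would read at this sulfur.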